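Three cytotoxicity limits and an unmeasured furan analogue

A few compounds are considered here, and "the series" means these few. Any claim that something is new, unique, unknown or untested is made for them only; others in the source may bear on it.

Compound 2 `CC(C)Oc1cccc(-c2ccc(C(=O)N(Cc3cccc(OCCCCCC(=O)O)c3)C(C)C)cc2)c1` carries a 3-isopropoxyphenyl group and a free carboxylic acid at the end of its chain. In an ADME assay on Raji cells (Homo sapiens) for cytotoxicity, read by CellTiter-Glo and resazurin assay, with a stated time of 72 h (a higher number here means that more compound is needed for the effect, a lower number that less compound is needed), compound 2 gives > 26000 nM, which is a limit of the assay and not a number. Compound 1 `CC(C)N(Cc1cccc(OCCCCCC(=O)O)c1)C(=O)c1ccc(-c2ccco2)cc1` differs from compound 2 by furan-2-yl in place of 3-isopropoxyphenyl on an aromatic carbon. In this assay compound 1 gives > 26000 nM, again a limit rather than a number. Compound 3 `CCOC(=O)CCCCCOc1cccc(CN(C(=O)c2ccc(-c3cccc(OC(C)C)c3)cc2)C(C)C)c1` differs from compound 2 by ethyl in place of hydrogen on an oxygen next to a carbonyl group. In this assay compound 3 gives > 26000 nM, also a limit. Accordingly the step that the two limits leave unreadable from compound 2 to compound 1 and the step that the two limits leave unreadable from compound 2 to compound 3 cannot be read in size, since the limit of > 26000 nM in this assay, at which 3 of the 3 values shown sit, is where every value shown sits.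

Compound 4 `CCOC(=O)CCCCCOc1cccc(CN(C(=O)c2ccc(-c3ccco3)cc2)C(C)C)c1` has not been measured in this assay. It differs from compound 3 by furan-2-yl in place of 3-isopropoxyphenyl on an aromatic carbon, and the difference between the two cores of compound 3 and compound 2 is the ethyl-for-hydrogen change already described. Among the compounds with values here, this is the same kind of change as the one from compound 2 to compound 1, made here on the ethyl ester rather than the acid. That earlier change left both compounds at the limit, so the step from compound 3 to compound 4 is expected to be a step that the limit leaves unreadable from compound 3 to compound 4, resting on compound 1 at > 26000 nM and compound 3 at > 26000 nM. Compound 4 is therefore estimated to give about 40000 nM in this assay, most likely reported only as a limit.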

Compound 4, half-maximal effective concentration: > 26000 nM
Compound 4 gave a limit, no number (the forecaster's own chance of this, stated with the estimate: 85%); the middle value is on the limit's open side.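

The steps from compound 3 to compound 4 and from compound 1 to compound 4 cannot be read in size, because all four compounds sit at the same limit of the assay and none gives a number: the limit of > 26000 nM in this assay, at which 4 of the 4 values shown sit.

The compounds shown leave open how far furan-2-yl and 3-isopropoxyphenyl, or the free acid and its ethyl ester, differ in this assay and whether any of the four would give a number there.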